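Swapping a Cyclic Sulfonamide Ring for a Methylimidazole

This account rests on a few compounds, and the source may have more. Where it says the series, first, only, none or still open, it means among the compounds named here.

Compound 1 `CC(C)C(c1ccc(-c2ccc3cccc(F)c3c2)[nH]c1=O)N1CCCCS1(=O)=O` carries a six-membered non-aromatic ring with 2 hetero atoms on a saturated chain carbon bound to an aromatic carbon and a saturated chain carbon. In an assay on CHO cells for displacement of a labelled ligand from prostaglandin E2 receptor EP3 subtype (Homo sapiens), read by radioligand binding (on this read-out lower numbers stand for stronger inhibition and higher numbers for weaker inhibition), compound 1 gives 14 nM. Of the two measured compounds it stands highest, the nearest being compound 2 `CC(C)C(c1nnc[nH]1)c1ccc(-c2ccc3cccc(F)c3c2)[nH]c1=O`, which in this assay gives 12 nM, a gap within the usual scatter.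

Compound 3 `Cc1c[nH]c(C(c2ccc(-c3ccc4cccc(F)c4c3)[nH]c2=O)C(C)C)n1` changes the same position: a group of 6 heavy atoms (4 carbon, 2 nitrogen; one five-membered aromatic ring with 2 hetero atoms) in place of a group of 8 heavy atoms (4 carbon, 1 nitrogen, 2 oxygen, 1 sulfur; one six-membered non-aromatic ring with 2 hetero atoms), on a saturated chain carbon bound to an aromatic carbon and a saturated chain carbon. Going by the values given here, one measured step bears on this: the move from compound 1 to compound 2, where a five-membered aromatic ring with hetero atoms also replaced the six-membered ring, and that move was a 1.2-fold lower number from compound 1 to compound 2 (0.07 log units; within the scatter). Because the step of a 1.2-fold lower number from compound 1 to compound 2 (0.07 log units; within the scatter) stayed within the scatter, and the group entering compound 3 is again a five-membered aromatic ring with hetero atoms, no step beyond the scatter is expected in this assay. Compound 3 is therefore estimated at 12 nM, in a range from 5 nM to 35 nM, an expected step of a 1.2-fold lower number from compound 1 to compound 3 (0.07 log units; within the scatter).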

Compound 3, inhibition constant: 12 nM
For compound 3 middle estimate and measured number coincide at the digits printed; the measured number falls inside the stated range.
By their numbers in this assay, from the lowest: compounds 2, 3 and 1 (each within the scatter of the next).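

In this assay the 4-methyl-1H-imidazol-2-yl of compound 3 is a second five-membered aromatic ring to take the place of the six-membered non-aromatic ring, and the result is a 1.2-fold lower number from compound 1 to compound 3 (0.07 log units; within the scatter) so the finding for compound 2 no longer rests on a single group. Placing 4-methyl-1H-imidazol-2-yl where 4H-1,2,4-triazol-3-yl stood gives no change at the digits printed from compound 2 to compound 3 (within the scatter) so this read-out does not separate these two five-membered aromatic rings, even with the added methyl on the one in compound 3. Nothing measured here explains why the three groups on this saturated chain carbon give such close numbers.

The compounds shown leave open whether this position would stay as undemanding for a group of another kind, such as a primary amine or a carboxylic acid, or for an open chain in place of a ring. They also leave open what the plain imidazole without its methyl would give, and whether a longer chain on the ring would finally move the number beyond the scatter.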